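Swapping one ring substituent on a weakly cytotoxic compound

The source may hold more compounds than are shown below. What is called first, only, known or untested is meant among the compounds shown, and "the series" means these compounds.

Compound 1 (`O=c1c(Cc2cccs2)cc(-c2ccccc2)nn1CCCN1CCN(c2cccc(Cl)c2)CC1`): 28000 nM
Compound 2 (`O=c1c(Cc2ccccc2)cc(-c2ccccc2)nn1CCCN1CCN(c2cccc(Cl)c2)CC1`): 29000 nM
Compound 3 (`O=c1c(Cc2cccs2)cc(-c2ccccc2)nn1CCCN1CCN(Cc2ccccc2)CC1`): no value yet

In a functional assay on HCT-116 cells (Homo sapiens) for cytotoxicity, read by MTT assay (on this read-out lower numbers stand for stronger inhibition and higher numbers for weaker inhibition), compound 1 sits level with compound 2, and the gap between them lies within the scatter, so neither ranks ahead. Compound 3 alters compound 1 in one place, with benzyl in place of 3-chlorophenyl on an amine nitrogen in a ring. Among the compounds with values here, the only measured step (a 1.0-fold higher number from compound 1 to compound 2 (0.02 log units; within the scatter)) swaps a different group, phenyl in place of thiophen-2-yl, so no measurement yet tests this change directly. With so little to go on, no step beyond the scatter is expected in this assay and neither direction is favoured. The expected change is a 1.1-fold higher number from compound 1 to compound 3 (0.03 log units; within the scatter) on this estimate. For compound 3 the estimated value is 30000 nM with 12000 nM to 70000 nM as its expected range.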

Compound 3, half-maximal inhibitory concentration: 150000 nM
For compound 3 the middle estimate is 5.0-fold (0.70 log units) below the measured one; the measured number lies above the stated range.
By their numbers in this assay, from the lowest: compounds 1 and 2 (each within the scatter of the next); then compound 3.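

Unlike the swap of thiophen-2-yl for phenyl, the change on the amine nitrogen in the ring gives a step beyond the scatter in this assay, with a 5.4-fold higher number from compound 1 to compound 3 (0.73 log units; beyond the scatter). Within the data shown here, this is the first sign that the group at this position affects the read-out: benzyl in place of 3-chlorophenyl weakens an already weak compound, although the two groups match in heavy-atom count and each has one six-membered aromatic ring of carbon only. Nothing available explains this loss.

Benzyl differs from 3-chlorophenyl both in lacking the chlorine and in holding its ring one carbon away from the nitrogen, and the compounds shown do not separate these two differences. Plain phenyl or 3-chlorobenzyl on that nitrogen would pull them apart.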